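A few compounds are considered here, and "the series" means these few. Any claim that something is new, unique, unknown or untested is made for them only; others in the source may bear on it.

Compound 1 `O=C(Nc1ccc(Cl)cc1)NS(=O)(=O)c1cccs1` is the reference of the series. In a functional assay on the whole organism (6C3HED cells, Mus musculus) for inhibition, at a dose of 300 mg/kg by the oral route (on this read-out higher numbers stand for more inhibition at the one dose given (going by the name of the read-out) and lower numbers for less inhibition), compound 1 gives 66%. Compound 2 `CCCOc1ccc(S(=O)(=O)NC(=O)Nc2ccc(Cl)cc2)s1` carries propoxy in place of hydrogen on an aromatic carbon of the same core; in this assay compound 2 gives 63%. Among the compounds with values here, the one measured step, a number 3 percentage points lower from compound 1 to compound 2 (within the scatter), shows that compound 1 and compound 2 cannot be told apart on this read-out, so compound 1 stands as a reference point with no measured neighbour separated from it beyond the scatter.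

Compound 3 `O=C(Nc1ccc(Cl)cc1)NS(=O)(=O)c1cc(Br)c(Br)s1` is not yet measured. 4,5-dibromothiophen-2-yl in place of thiophen-2-yl on a sulfonyl sulfur

Within the data shown here, the only step in hand, substitution on the same ring in compound 2, was within the scatter, so no measured step speaks for a move of either sign. Compound 3 is therefore expected to give 63% (range 42% to 80%), a step estimated as a number 3 percentage points lower from compound 1 to compound 3 (within the scatter), none beyond the scatter.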

Compound 3, a percentage reported as inhibition, in the whole organism at one dose (the size of the read-out at that dose, not a potency): 52%
For compound 3 the middle estimate is 11 percentage points above the measured one; the range from low to high includes it.
By their numbers in this assay, from the lowest: compound 3; then compounds 2 and 1 (each within the scatter of the next).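

In this assay, within the data shown here, the change on the sulfonyl sulfur from thiophen-2-yl to 4,5-dibromothiophen-2-yl gives the only step beyond the scatter (a number 14 percentage points lower from compound 1 to compound 3 (beyond the scatter)). This position therefore does not take every change without loss, whereas the propoxy change stayed within the scatter (a number 3 percentage points lower from compound 1 to compound 2 (within the scatter)). These are two different changes, so they set no rule for substitution on this ring, and the size of the drop remains modest. Nothing in hand gives a reason for the drop.

Open, from the compounds shown here alone, is whether a single bromine carries the same step or both are needed. Also open, going by these compounds, is whether fluorine, methyl or an amine on the same ring stays within the scatter of compound 1.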